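The source may report more compounds than this note shows. Statements on the series, on what has been measured and on what is new or still open speak of the compounds shown alone.

Among the compounds with values here, compound 2 `Clc1ccc(-c2cn3ccnc3c(-c3ccc4ncn(C5CCCCC5)c4c3)n2)cc1` gives the higher of the two numbers measured so far: in a functional assay on K562 cells (Homo sapiens) for inhibition, read by sulforhodamine B assay, with a stated time of 48 h, tested at 10 uM (a higher number here means more inhibition at the concentration tested (going by the name of the read-out), a lower number less inhibition), compound 2 reaches 44.5%, while compound 1 `c1ccc2c(-c3cn4ccnc4c(-c4ccc5ncn(C6CCCCC6)c5c4)n3)cccc2c1` gives 30.9%. Within the data shown here, the single measured step, a number 13.6 percentage points higher from compound 1 to compound 2 (beyond the scatter), altered the group at this same position. Compound 3 `COc1ccccc1-c1cn2ccnc2c(-c2ccc3ncn(C4CCCCC4)c3c2)n1` differs from compound 2 by 2-methoxyphenyl in place of 4-chlorophenyl on an aromatic carbon. Among the measured compounds shown here, no measured step swaps these two groups, so the only guide is that a change here moved the number modestly. The step of a number 6.5 percentage points lower from compound 2 to compound 3 (within the scatter) is expected to stay within the scatter. The estimate for compound 3 is 38%, with a range from 18% to 58%.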

Compound 3, a percentage reported as inhibition, at one concentration (the size of the read-out at that concentration, not a potency): 22.6%
The estimate for compound 3 lay 15.4 percentage points above the measured number; the range from low to high includes it.
By their numbers in this assay, from the lowest: compounds 3 and 1 (each within the scatter of the next); then compound 2.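

In this assay, 2-methoxyphenyl in place of 4-chlorophenyl gives a number 21.9 percentage points lower from compound 2 to compound 3 (beyond the scatter) and so marks a second step beyond the scatter at this position. Replacing naphthalen-1-yl with 2-methoxyphenyl gives a number 8.3 percentage points lower from compound 1 to compound 3 (within the scatter) and does not separate these two groups, leaving 4-chlorophenyl alone above both. No measured evidence explains this difference. The compounds shown leave open whether the higher number follows the chlorine or its place on the phenyl ring. A comparison of 2-chlorophenyl and 4-methoxyphenyl at this position would separate those two possibilities.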